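Amine swap on the benzylic side chain, compound 3 to 4

A few compounds are considered here, and "the series" means these few. Any claim that something is new, unique, unknown or untested is made for them only; others in the source may bear on it.

Compound 3 `CC1CCN(Cc2ccc3nc(NC(=O)N/N=C/c4cn(Cc5ccc(Cl)cc5)c5ccccc45)sc3c2)CC1` gives 2030 nM in a functional assay on A549 cells (Homo sapiens) for cytotoxicity, read by MTT assay, with a stated time of 72 h; a lower number here means a stronger inhibitor, a higher number a weaker inhibitor. Its number is the highest of the three measured, yet the gaps to compound 1 `CCN(CC)Cc1ccc2nc(NC(=O)N/N=C/c3cn(Cc4ccc(Cl)cc4Cl)c4ccccc34)sc2c1`, which gives 1900 nM, and to compound 2 `CCN(CC)Cc1ccc2nc(NC(=O)N/N=C/c3cn(Cc4ccc(Cl)c(Cl)c4)c4ccccc34)sc2c1`, which gives 1470 nM, both lie within the scatter, so the three compounds cannot be ordered on these data.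

Compound 4 `CCN(CC)Cc1ccc2nc(NC(=O)N/N=C/c3cn(Cc4ccc(Cl)cc4)c4ccccc34)sc2c1` differs from compound 3 in one place: diethylamino in place of 4-methylpiperidin-1-yl on a saturated chain carbon bound to an aromatic carbon. Compound 4 carries the same phenyl substitution as compound 3 and the same diethylamino group as compound 1 and compound 2.

Within the data shown here, the only measured step, a 1.3-fold lower number from compound 1 to compound 2 (0.11 log units; within the scatter), concerns the chlorine pattern on the phenyl ring, not the amine, so no step bears directly on the present change. Compound 1 and compound 2 with diethylamino and compound 3 with 4-methylpiperidin-1-yl all sit within the scatter of one another, which gives no reason to expect a step beyond the scatter in either direction.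

Compound 4 is therefore expected to give about 1700 nM in this assay, between 800 nM and 3600 nM, a step of a 1.2-fold lower number from compound 3 to compound 4 (0.08 log units; within the scatter) that is estimated to stay within the scatter.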

Compound 4, half-maximal inhibitory concentration: 2940 nM
Compound 4: middle estimate off by 1.7-fold (0.24 log units), on the low side, and the stated range covers the measured number.
By their numbers in this assay, from the lowest: compounds 2, 1, 3 and 4 (each within the scatter of the next).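

In this assay, the amine on the saturated chain carbon bound to an aromatic carbon now has a direct reading: diethylamino in place of 4-methylpiperidin-1-yl gives a 1.4-fold higher number from compound 3 to compound 4 (0.16 log units; within the scatter) and so does not separate the ring from the open-chain amine. Hydrogen in place of chloro on an aromatic carbon gives a 1.5-fold higher number from compound 1 to compound 4 (0.19 log units; within the scatter) and a 2.0-fold higher number from compound 2 to compound 4 (0.30 log units; within the scatter), so neither chlorine removal moves the number beyond the scatter, and the series so far shows no single change that does. No measurement at hand accounts for these numbers.

Still open, going by these compounds, is whether morpholin-4-yl or a side chain without an amine, such as methoxymethyl, would leave the number within the scatter at this place. Also open, on these data alone, is whether a carboxylic acid or a methoxy group on the phenyl ring would do the same.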